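Removing the methoxy group: compound 2 to compound 3

The compounds below may be only part of what the source reports. "The series", "measured", "known", "first", "only" and "open" are said of these compounds alone.

Two compounds of this series carry a value in an assay on CHO-K1 cells for inhibition of sodium-dependent dopamine transporter (Homo sapiens); a lower number here means a stronger inhibitor, a higher number a weaker inhibitor. Compound 1 `COc1ccc([C@]23CCC[C@H]2CN(C)C3)cc1` reaches only the limit of the method there; in this assay compound 1 gives > 10000 nM, which is a limit and not a number. For the measured compounds named here, compound 2 `COc1ccc([C@]23CCCC[C@H]2CN(C)C3)cc1` is the only member with a measured number: in this assay compound 2 gives 1000 nM. Among the values shown, compound 2 therefore stands alone as a number, the one further value being the limit just mentioned (the limit of > 10000 nM in this assay, at which 1 of the 2 values shown sits). Going by the values given here, no step between two measured compounds that differ in a single place exists, so no measured change carries over to the next compound.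

Compound 3 `CN1C[C@@H]2CCCC[C@]2(c2ccccc2)C1` is not yet measured in this assay. It differs from compound 2 by hydrogen in place of methoxy on an aromatic carbon. Among the compounds with values here, with no measured step of this kind available, the expectation rests on compound 2 alone, and the step is expected to be small, at most a modest loss, a 1.5-fold higher number from compound 2 to compound 3 (0.18 log units; within the scatter). In this assay compound 3 is accordingly estimated at 1500 nM, within 400 nM to 6000 nM.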

Compound 3, half-maximal inhibitory concentration: 1580 nM
Beside the measured number, compound 3's estimate is 1.1-fold (0.02 log units) below it; measured number inside the range.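

In this assay the series now has its first readable step: hydrogen in place of methoxy on an aromatic carbon, para to a large group, gives a 1.6-fold higher number from compound 2 to compound 3 (0.20 log units; within the scatter) for this single change. At this position, then, the methoxy group can be lost without a change that stands out from the scatter, and compound 2 and compound 3 cannot be told apart in this assay on these numbers, so the oxygen-bearing group is not required for the level of inhibition seen in compound 2. Nothing measured in the material shown bears on why this step has the size it has.

Still open, as far as these compounds go, is whether a chlorine atom, a hydroxyl group or a longer ether chain such as ethoxy on the same aromatic carbon would move the number beyond the scatter in either direction, and whether an ethyl group in place of the methyl on the amine would do so. Compound 1 remains a limit and not a number, so no step involving it can be read: the limit of > 10000 nM in this assay, at which 1 of the 3 values shown sits.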